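The source may hold more compounds than are shown below. What is called first, only, known or untested is meant among the compounds shown, and "the series" means these compounds.

Measured compounds:
compound 1 `CN(C)/C(=N/CCCCn1nc(-c2ccccc2)ccc1=O)NC#N` gives 80.7% in a functional assay on the whole organism with Rattus norvegicus as the target, at a dose of 100 mg/kg; a lower number here means less inhibition, a higher number more inhibition at the dose given (going by the name of the read-out);
compound 2 `CC/N=C(\S)NCCCCCn1nc(-c2ccccc2)ccc1=O` gives 66.4%;
compound 3 `O=c1ccc(-c2ccccc2)nn1CCCCNC(=S)NC1CCCCC1` gives 18.1%.

Compound 3 stands lowest of the three numbers in this assay; compound 2 is nearest, and compound 1 furthest, both beyond the scatter. Compound 4 `CC(C)(C)/N=C(\S)NCCCCn1nc(-c2ccccc2)ccc1=O` has not yet been measured. It differs from compound 3 by a group of 7 heavy atoms (5 carbon, 1 nitrogen, 1 sulfur; no ring) in place of a group of 9 heavy atoms (7 carbon, 1 nitrogen, 1 sulfur; one six-membered non-aromatic ring of carbon only), on an amine nitrogen. Within the data shown here, only one step between measured compounds is known, a number 14.3 percentage points lower from compound 1 to compound 2 (beyond the scatter), and it changes a group on a saturated chain carbon, not on the amine nitrogen, so it bears little on the present change. Among the measured compounds shown here, compounds 2 and 3 both carry a thiourea, and their values show that the compound with the ring-bearing group sits far below the one with the short chain-bearing group, though no single step links them. Compound 4 carries a chain-bearing group again, so an upward step a number 26.9 percentage points higher from compound 3 to compound 4 (beyond the scatter) is expected, with a wide spread. Compound 4 is therefore estimated at 45%, within 15% to 75%.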

Compound 4, a percentage reported as inhibition, in the whole organism at one dose (the size of the read-out at that dose, not a potency): 33.6%
Compound 4: the middle estimate sits 11.4 percentage points above what was measured, and the stated range covers the measured number.
By their numbers in this assay, from the lowest: compound 3; then compound 4; then compound 2; then compound 1.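

In this assay, among these compounds, the first step confined to the amine nitrogen, the no-ring group of 7 heavy atoms entering for the group of 9 heavy atoms with its six-membered carbon ring, gives a number 15.5 percentage points higher from compound 3 to compound 4 (beyond the scatter), a modest change beyond the scatter. This shows that the group at this place affects the read-out, but removing the ring recovers only part of the distance to the other compounds. The two large steps, a number 32.8 percentage points lower from compound 2 to compound 4 (beyond the scatter) and a number 47.1 percentage points lower from compound 1 to compound 4 (beyond the scatter), show that a ring-free group alone does not bring the number to the level of the upper pair.

Nothing available explains these differences. Going by these compounds, what a methyl group or a phenyl ring on that amine nitrogen would give remains open, as does the effect of a urea carbonyl in place of the sulfur on the butyl-linked core.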